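The compounds below may be only part of what the source reports. "The series", "measured", "known", "first", "only" and "open" are said of these compounds alone.

Measured compounds:

- compound 1 `C=C1C[C@]23C[C@@]1(O)CC[C@H]2c1ccc(OS(=O)(=O)c2ccc(C)cc2)c(C)c1[C@@H]3Cn1cc(-c2ccc(F)cc2)nn1`: in a functional assay on SMMC-7721 cells (Homo sapiens) for cytotoxicity, read by MTT assay, with a stated time of 4 days (a lower number here means a stronger inhibitor, a higher number a weaker inhibitor), compound 1 gives > 20000 nM
- compound 2 `C=C1C[C@]23C[C@@]1(O)CC[C@H]2c1ccc(O)c(C)c1[C@@H]3Cn1cc(-c2ccccc2)nn1`: in this assay compound 2 gives > 20000 nM

Neither entry is a number. Compound 2 sits at the limit of > 20000 nM in this assay, at which 2 of the 2 values shown sit, which is a limit of the assay rather than a measured potency, so all that is known is that compound 2 did not reach a half-maximal effect within the tested range. The same is true of compound 1, whose entry is also a limit. Among the measured compounds shown here, with both values being limits, no step between measured compounds can be counted, and there is no measured guide for what a single change does in this assay.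

Compound 3 `C=C1C[C@]23C[C@@]1(O)CC[C@H]2c1ccc(O)c(C)c1[C@@H]3Cn1cc(-c2ccc(F)cc2)nn1` differs from compound 2 in one place: fluoro in place of hydrogen on an aromatic carbon, a fluoro in place of hydrogen on an aromatic carbon, read one bond further out as phenyl to 4-fluorophenyl. For the measured compounds named here, nothing among the measured compounds shows this change acting on its own. The expected step that the limit leaves unreadable from compound 2 to compound 3 is therefore none beyond the usual scatter. Compound 3 is estimated at 25000 nM, between 8000 nM and 80000 nM, and most probably it would again be reported only as a limit.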

Compound 3, half-maximal inhibitory concentration: > 20000 nM
Compound 3: no number, only a limit; the forecaster's own chance of this, stated with the estimate: 75%; the middle value does not contradict the limit.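

In this assay compound 3 gives > 20000 nM as a limit, not a number. Among the compounds shown here, no step from compound 1 or compound 2 to compound 3 can be read, because all three entries are limits: the limit of > 20000 nM in this assay, at which 3 of the 3 values shown sit. The compounds shown leave open how potent each one is in these cells and whether the fluoro changes that potency.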